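The source may hold more compounds than are shown below. What is called first, only, known or untested is meant among the compounds shown, and "the series" means these compounds.

Measured compounds:
- compound 1, `CCOC(=O)c1c(N)sc(-c2ccc(C(C)=O)cc2)c1-c1cccc(C(F)(F)F)c1`, in an assay on CHO-K1 cells for displacement of a labelled ligand from adenosine receptor A1 (Homo sapiens), tested at 10 uM; on this read-out higher numbers stand for more inhibition at the one concentration tested (going by the name of the read-out) and lower numbers for less inhibition: 64.6%
- compound 2, `CCOC(=O)c1c(N)sc(-c2ccc([N+](=O)[O-])cc2)c1-c1cccc(C(F)(F)F)c1`, in this assay: 71.4%

Both measured compounds share the same core and differ only in the group carried on an aromatic carbon of the outer six-membered ring. Among the compounds with values here, the one measured step, a number 6.8 percentage points higher from compound 1 to compound 2 (within the scatter), stays within the scatter, so compound 2 and compound 1 cannot be told apart on these two numbers: compound 2 stands level with compound 1 rather than apart from it.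

Compound 3, `CCOC(=O)c1c(N)sc(-c2ccc(C(F)(F)F)cc2)c1-c1cccc(C(F)(F)F)c1`, has not yet been measured. It is reached from compound 2 by the change (trifluoromethyl in place of nitro on an aromatic carbon). Within the data shown here, no measured pair shows this exchange; the only step at hand, a number 6.8 percentage points higher from compound 1 to compound 2 (within the scatter), swaps one group on that same aromatic carbon for another without moving the read-out beyond the scatter. On that basis the expectation for compound 3 is a change of about a number 6.4 percentage points lower from compound 2 to compound 3 (within the scatter), that is, none beyond the scatter. Compound 3 is therefore estimated at 65%, within a range from 45% to 85%.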

Compound 3, a percentage reported as inhibition, at one concentration (the size of the read-out at that concentration, not a potency): 48.5%
Compound 3: the middle estimate sits 16.5 percentage points above what was measured, and the stated range covers the measured number.
By their numbers in this assay, from the lowest: compound 3; then compounds 1 and 2 (each within the scatter of the next).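

The group on the aromatic carbon para to a large group does matter in this assay: the first pair left that reading open, since its exchange did not move the number beyond the scatter. Trifluoromethyl in place of nitro gives a number 22.9 percentage points lower from compound 2 to compound 3 (beyond the scatter) and trifluoromethyl in place of acetyl gives a number 16.1 percentage points lower from compound 1 to compound 3 (beyond the scatter) so both steps to compound 3 lie beyond the scatter, and compound 3 stands apart from compound 1 and compound 2, which remain level with each other. Among these three compounds, then, the read-out separates trifluoromethyl from the other two groups, but nothing available accounts for that separation.

As far as these compounds go, whether an amine, a carboxylic acid or a longer chain on this same carbon would stand with compound 3 or with compound 1 and compound 2 stays open, and three groups cannot show whether any trend runs through them. Also open, from the compounds shown here alone, is whether the drop seen with trifluoromethyl would hold if the ethyl ester or the amine of the shared core were replaced by another group.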